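The source may report more compounds than this note shows. Statements on the series, on what has been measured and on what is new or still open speak of the compounds shown alone.

Measured in a functional assay on the whole organism (Tail, strain ICR) with Mus musculus as the target, in the tail flick test, with a stated time of 120 min, at a dose of 25 umol/kg by the oral route; on this read-out lower numbers stand for a weaker effect and higher numbers for a stronger effect at the one dose given:
compound 1 `NC(=O)C[C@H](NC(=O)CN(c1nc(Cl)nc2[nH]cnc12)C1CC1)C(=O)O` gives 17%
compound 2 `CC(C)C[C@H](NC(=O)CN(c1nc(Cl)nc2[nH]cnc12)C1CC1)C(=O)OCc1ccccc1` gives 8.58%
compound 3 `CC(C)C[C@H](NC(=O)CN(c1nc(Cl)nc2[nH]cnc12)C1CC1)C(=O)O` gives 18.7%

Compound 3 and compound 1 share a core and differ by carbamoyl in place of isopropyl on a saturated chain carbon, two bonds along the chain from an amide-type nitrogen and a carbonyl carbon; this change gave a number 1.7 percentage points lower from compound 3 to compound 1 (within the scatter). Compound 2 carries the core of compound 3 with a changed ester end, the difference being (benzyl in place of hydrogen on an oxygen next to a carbonyl group); the step of a number 10.1 percentage points higher from compound 2 to compound 3 (beyond the scatter) is the only one beyond the scatter among these three compounds. Compound 1 and compound 2 lie within the scatter of each other, so no order between them is claimed.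

Compound 4 `NC(=O)C[C@H](NC(=O)CN(c1nc(Cl)nc2[nH]cnc12)C1CC1)C(=O)OCc1ccccc1` is not yet measured in this assay. It stands to compound 2 as compound 1 stands to compound 3: the difference is carbamoyl in place of isopropyl on a saturated chain carbon, two bonds along the chain from an amide-type nitrogen and a carbonyl carbon, the same change at the same place, made on the core of compound 2 rather than on that of compound 3. Because the earlier step of a number 1.7 percentage points lower from compound 3 to compound 1 (within the scatter) stayed within the scatter, a step of similar size is expected here, a number 1.6 percentage points lower from compound 2 to compound 4 (within the scatter), resting on that single example. The value for compound 4 is estimated as 7%, expected to fall between 0% and 17%.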

Compound 4, a percentage reported as activity, at one dose (the size of the read-out at that dose, not a potency): 15.1%
Compound 4: middle estimate off by 8.1 percentage points, on the low side; low and high end bracket the measured number.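

Carbamoyl in place of isopropyl gives a number 6.5 percentage points higher from compound 2 to compound 4 (within the scatter) in this assay, and the two steps for this change cannot be told apart: the same change on two cores in this assay, a number 1.7 percentage points lower (within the scatter) from compound 3 to compound 1 and a number 6.5 percentage points higher (within the scatter) from compound 2 to compound 4, 8.2 percentage points apart, within the scatter of two such steps. Benzyl in place of hydrogen on the oxygen gives a number 1.9 percentage points lower from compound 1 to compound 4 (within the scatter), and this step likewise cannot be told apart from its counterpart on the other core, even though only the counterpart lies beyond the scatter: the same change on two cores in this assay, a number 10.1 percentage points higher (beyond the scatter) from compound 2 to compound 3 and a number 1.9 percentage points higher (within the scatter) from compound 4 to compound 1, 8.2 percentage points apart, within the scatter of two such steps. Neither change can therefore be said to behave differently on the two cores, but this does not show that either change carries over unaltered, as each comparison rests on one pair of steps at a single dose and a single time.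

Still open, from the compounds shown here alone, is how a longer chain or an amine would read on that saturated chain carbon, in place of isopropyl or carbamoyl. Also open, going by these compounds, is whether a methyl or ethyl group on the oxygen, in place of benzyl, would follow the same steps on both cores.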